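Working notes: anilino substituent swap on the shared core

The source may report more compounds than this note shows. Statements on the series, on what has been measured and on what is new or still open speak of the compounds shown alone.

Measured compounds:
compound 1 `CNc1nnc(-c2nsc3ccccc23)o1` gives 10%
compound 2 `CCNc1nnc(-c2nsc3ccccc23)o1` gives 29%
compound 3 `Clc1ccc(Nc2nnc(-c3nsc4ccccc34)o2)cc1` gives 10%

In a functional assay on the whole organism for inhibition, with Rattus norvegicus as the target, with a stated time of 3.5 h, at a dose of 100 mg/kg by the oral route (a higher number here means more inhibition at the dose given (going by the name of the read-out), a lower number less inhibition), compound 3 stands level with compound 1, the two together being the lowest of the three numbers: no change at the digits printed from compound 1 to compound 3 (within the scatter). Against compound 2 the difference is a number 19 percentage points lower from compound 2 to compound 3 (beyond the scatter), and the only step that moved the read-out beyond the scatter is a number 19 percentage points higher from compound 1 to compound 2 (beyond the scatter).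

Compound 4 `COc1ccc(Nc2nnc(-c3nsc4ccccc34)o2)cc1` is not yet measured. It differs from compound 3 in one place: methoxy in place of chloro on an aromatic carbon. Among the measured compounds shown here, no measured step varies a group on the six-membered aromatic ring itself; the steps on hand only exchange the whole substituent on the nitrogen on the aromatic ring, and the aryl case sits low. Nothing therefore points to a move beyond the scatter in either direction, and the number for compound 4 is expected to stay close to that of compound 3, with a number 2 percentage points higher from compound 3 to compound 4 (within the scatter) as the expected step. The estimate for compound 4 is 12%, within 0% to 32%.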

Compound 4, a percentage reported as inhibition, in the whole organism at one dose (the size of the read-out at that dose, not a potency): 33%
Compound 4: the middle estimate sits 21 percentage points below what was measured; measured number outside the range, above it.
By their numbers in this assay, from the lowest: compounds 1 and 3 (each within the scatter of the next); then compounds 2 and 4 (each within the scatter of the next).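

In this assay, the substituent on the six-membered aromatic ring proves able to move the read-out: methoxy in place of chloro, para to a large group, gives a number 23 percentage points higher from compound 3 to compound 4 (beyond the scatter). Among the compounds shown here, the earlier steps exchanged only the whole substituent on the nitrogen, so this is the first sign that an aryl group there does not by itself hold the number low, and that the group carried on that ring matters. No measurement on hand bears on the reason for this step.

On these data alone, whether the gain requires the methyl on the oxygen stays open, and a hydroxy group at the same place would test that. Whether it extends to an amine or a longer ether such as ethoxy is also unresolved.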